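This account rests on a few compounds, and the source may have more. Where it says the series, first, only, none or still open, it means among the compounds named here.

Working notes on the phenoxyacetamide series.

Three members of the series have been run in a functional assay on A549 cells (Homo sapiens) for cytotoxicity, read by trypan blue exclusion, with a stated time of 48 h; on this read-out higher numbers stand for weaker inhibition and lower numbers for stronger inhibition. Compound 1 `Cc1cc(OCC(=O)Nc2nc(-c3ccc(Br)cc3)cs2)ccc1Cl` gives 51700 nM. Compound 2 `O=C(COc1ccccc1)Nc1nc(-c2ccc(Br)cc2)cs1` gives 52200 nM. Compound 3 `Cc1ccccc1OCC(=O)Nc1nc(-c2ccc(Br)cc2)cs1` gives 49800 nM. On these numbers compound 3 sits together with compound 1 and compound 2; the three values lie within the scatter of one another, so no ranking among them can be drawn.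

The next member is compound 4 `Cc1ccc(OCC(=O)Nc2nc(-c3ccc(Br)cc3)cs2)cc1`, not yet measured in this assay. Relative to compound 3 the change is 4-methylphenyl in place of 2-methylphenyl on an oxygen on a saturated carbon.

The steps measured so far all concern the same oxygen-bound aryl group. For the measured compounds named here, the step of a 1.0-fold higher number from compound 1 to compound 2 (0.00 log units; within the scatter), the step of a 1.0-fold lower number from compound 1 to compound 3 (0.02 log units; within the scatter) and the step of a 1.0-fold lower number from compound 2 to compound 3 (0.02 log units; within the scatter) each stay within the scatter, although none of them swaps one methylphenyl for another, so the present change has no exact precedent. With every variation of that aryl group so far leaving the read-out in this assay unchanged beyond the scatter, the expectation for compound 4 is a step of a 1.0-fold higher number from compound 3 to compound 4 (0.00 log units; within the scatter), in no particular direction. The estimate for compound 4 in this assay is therefore 50000 nM, with a range from 25000 nM to 100000 nM.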

Compound 4, half-maximal inhibitory concentration: 58600 nM
For compound 4 the middle estimate is 1.2-fold (0.07 log units) below the measured one; the range from low to high includes it.
By their numbers in this assay, from the lowest: compounds 3, 1, 2 and 4 (each within the scatter of the next).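

For the compounds shown here, the change from 2-methylphenyl to 4-methylphenyl is the first step that relocates the methyl group with the atom count held fixed, and in this assay a 1.2-fold higher number from compound 3 to compound 4 (0.07 log units; within the scatter) stays within the scatter, so these two placements of the methyl group cannot be told apart. The other new steps, a 1.1-fold higher number from compound 2 to compound 4 (0.05 log units; within the scatter) for methyl in place of hydrogen on an aromatic carbon and a 1.1-fold higher number from compound 1 to compound 4 (0.05 log units; within the scatter) for 4-methylphenyl in place of 4-chloro-3-methylphenyl, are also within the scatter, so phenyl, 2-methylphenyl, 4-methylphenyl and 4-chloro-3-methylphenyl on an oxygen on a saturated carbon give no ranking in this assay. No measurement is available that bears on this lack of separation.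

The compounds shown carry only hydrocarbon and chloro substituents at this place, so it remains open whether an amine or a carboxylic acid on the aryl group would shift the number in this assay. As far as these compounds go, it is equally open whether a longer chain in place of the oxymethylene link, or any change to the shared core, would do so.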